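The source may report more compounds than this note shows. Statements on the series, on what has been measured and on what is new or still open speak of the compounds shown alone.

Compound 1 `COc1ccc(/C=C/C(=O)c2c(C)cc(O)c(C(=O)/C=C/c3ccc(OC)cc3)c2-c2ccccc2)cc1` carries a shared core with a methyl group and a hydroxyl group on a central aromatic ring, two cinnamoyl arms bearing methoxy groups, and a pendant phenyl ring. In a functional assay on MCF7 cells (Homo sapiens) for cytotoxicity, read by MTT assay, with a stated time of 24 h (a lower number here means a stronger inhibitor, a higher number a weaker inhibitor), compound 1 gives "not active" (no number reported), so no single number stands for it; it is one of two entries without a number. Compound 2 `COc1ccc(/C=C/C(=O)c2c(C)cc(O)c(C(=O)/C=C/c3ccc(OC)c(OC)c3)c2-c2ccccc2)cc1OC` differs from compound 1 in the methoxy pattern of the arms; in this assay compound 2 also gives "not active" (no number reported). Among the compounds with values here, compound 3 `Cc1cc(O)c(C(=O)/C=C/c2ccc(OCc3ccccc3)cc2)c(-c2ccc(Br)cc2)c1C(=O)/C=C/c1ccc(OCc2ccccc2)cc1`, with a bromine on the pendant ring and benzyloxy groups on the arms, is the only compound with a number, giving 20000 nM in this assay, a weak result.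

Compound 4 `COc1ccc(/C=C/C(=O)c2c(C)cc(O)c(C(=O)/C=C/c3ccc(OC)cc3)c2-c2ccc(OCc3ccccc3)cc2)cc1` is made from compound 1 by one change: benzyloxy in place of hydrogen on an aromatic carbon. Within the data shown here, no measured pair shows what this change does here. Given that compound 1 gives "not active" (no number reported) and that the one compound with a number, compound 3, shows only weak inhibition, the step in this assay is expected to be small, if any, and compound 4 is likely to remain weak. Compound 4 is estimated at 30000 nM, with a range from 8000 nM to 100000 nM.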

Compound 4, half-maximal inhibitory concentration: 30000 nM
Compound 4: middle estimate and measured number agree at the digits printed, and the stated range covers the measured number.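

Within the data shown here, compound 4 has a measured number while compound 1 has none, so no step from one to the other can be read. The compounds shown leave open what adding benzyloxy in place of hydrogen does to the activity of compound 1. Nothing measured here offers an explanation for the result of compound 4.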